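This account rests on a few compounds, and the source may have more. Where it says the series, first, only, none or still open, it means among the compounds named here.

Working notes on the imidazole-nitrogen substituent in this series. Compound 3 `CC(C)Cn1c(-c2ccc(OCc3c(-c4c(Cl)cccc4Cl)noc3C(C)C)cc2)nc2ccc(C(=O)O)cc21` gives 1180 nM in an assay on HEK-293T cells for antagonist activity at vitamin D3 receptor (Homo sapiens), read by a luciferase reporter, with a stated time of 24 h; on this read-out higher numbers stand for weaker inhibition and lower numbers for stronger inhibition; it stands second highest of the three numbers, nearest compound 1 `CC(C)c1onc(-c2c(Cl)cccc2Cl)c1COc1ccc(-c2nc3ccc(C(=O)O)cc3n2CC(C)(C)C)cc1` at 861 nM and furthest from compound 2 `CC(C)c1onc(-c2c(Cl)cccc2Cl)c1COc1ccc(-c2nc3ccc(C(=O)O)cc3n2C(C)C)cc1` at 3550 nM. The steps at this position are a 4.1-fold higher number from compound 1 to compound 2 (0.62 log units; beyond the scatter) and a 3.0-fold lower number from compound 2 to compound 3 (0.48 log units; beyond the scatter), while a 1.4-fold higher number from compound 1 to compound 3 (0.14 log units; within the scatter). Compound 4 `CC(C)c1onc(-c2c(Cl)cccc2Cl)c1COc1ccc(-c2nc3ccc(C(=O)O)cc3n2C2CCCCC2)cc1` carries cyclohexyl in place of isobutyl on an aromatic nitrogen. The two steps that bear on it point the same way, a larger group on the aromatic nitrogen giving a lower number, so only a small step is expected, a 1.3-fold lower number from compound 3 to compound 4 (0.12 log units; within the scatter), with wide uncertainty since no ring has been tried here. Compound 4 is estimated at 900 nM in this assay, within 250 nM to 3500 nM.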

Compound 4, half-maximal inhibitory concentration: 1450 nM
For compound 4 the middle estimate is 1.6-fold (0.21 log units) below the measured one; measured number inside the range.
By their numbers in this assay, from the lowest: compounds 1, 3 and 4 (each within the scatter of the next); then compound 2.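

Cyclohexyl, the only ring tried on this aromatic nitrogen, does not extend the earlier reading that a larger group gives a lower number: a 1.2-fold higher number from compound 3 to compound 4 (0.09 log units; within the scatter) and a 1.7-fold higher number from compound 1 to compound 4 (0.23 log units; within the scatter) are both within the scatter. Cyclohexyl, isobutyl and neopentyl therefore cannot be told apart here, and compound 2 with its isopropyl remains the one that stands apart, with a 2.4-fold lower number from compound 2 to compound 4 (0.39 log units; beyond the scatter) adding a third step beyond the scatter. Nothing at hand explains this. Open, on these data alone, is whether a smaller ring such as cyclopropyl, a longer chain, or a chain carrying an amine would leave the number in this range.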